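The source may report more compounds than this note shows. Statements on the series, on what has been measured and on what is new or still open speak of the compounds shown alone.

In a functional assay on U-937 cells (Homo sapiens) for antiproliferative activity, with a stated time of 48 h (on this read-out lower numbers stand for an effect already at smaller amounts and higher numbers for an effect only at larger amounts of compound), compound 3 (`N#Cc1ccc(NC(=O)CCCCCCC(=O)NO)cc1`) gives 7000 nM and sits at the high end of the numbers, together with compound 1 (`O=C(CCCCCCC(=O)Nc1ccc(O)cc1)NO`) at 6400 nM in that read-out. Compound 2 (`O=C(CCCCCCC(=O)Nc1ccc(I)cc1)NO`) stands well apart and gives 120 nM by contrast. Compound 4 (`CN(C)c1ccc(NC(=O)CCCCCCC(=O)NO)cc1`) has dimethylamino in place of cyano on an aromatic carbon. Among the compounds with values here, no measured step involves dimethylamino, so the evidence is indirect. Within the data shown here, the steps that bear on it are swaps at the same place. Of these, a 1.1-fold higher number from compound 1 to compound 3 (0.04 log units; within the scatter) stays within the scatter, while a 53-fold lower number from compound 1 to compound 2 (1.73 log units; beyond the scatter) and a 58-fold higher number from compound 2 to compound 3 (1.77 log units; beyond the scatter) are both large. This place can therefore move the number strongly, although only iodo has done so. In this assay a moderate step toward a lower number is expected, much smaller than those large steps, and a step within the scatter remains possible. The estimated change is a 4.7-fold lower number from compound 3 to compound 4 (0.67 log units; beyond the scatter) in this expectation. For compound 4 the estimated value is 1500 nM with an expected range from 250 nM to 7000 nM in this assay.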

Compound 4, half-maximal effective concentration: 1700 nM
Estimate against measurement, compound 4: 1.1-fold (0.05 log units) below; the range from low to high includes it.
By their numbers in this assay, from the lowest: compound 2; then compound 4; then compounds 1 and 3 (each within the scatter of the next).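

In this assay dimethylamino gives the first intermediate result at this place, with a 4.1-fold lower number from compound 3 to compound 4 (0.61 log units; beyond the scatter) and a 3.8-fold lower number from compound 1 to compound 4 (0.58 log units; beyond the scatter) both beyond the scatter. The place therefore no longer divides simply into iodo on one side and hydroxy and cyano on the other. Iodo still stands apart, since a 14-fold higher number from compound 2 to compound 4 (1.15 log units; beyond the scatter) is a large step, and dimethylamino covers only part of the distance to compound 2. Nothing given here explains why these groups differ in this way.

As far as these compounds go, it remains open whether a simple amine, a methoxy group or bromo at this place would fall nearer to iodo or to dimethylamino. From the compounds shown here alone, it also remains open whether the same order of groups would hold with a longer chain in the shared core.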